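The source may hold more compounds than are shown below. What is called first, only, known or untested is meant among the compounds shown, and "the series" means these compounds.

Compound 2 `COC(=O)c1ccc(/N=N/N(C)C(=O)CCc2cccc(O)c2)cc1` gives 7.8 h in an ADME assay on a cell-free system (plasma, Homo sapiens) for metabolic stability, read by HPLC (on this read-out lower numbers stand for a shorter-lived compound and higher numbers for a longer-lived compound), and stands second highest of the three numbers shown. For the measured compounds named here, compound 3 `CC(=O)c1ccc(/N=N/N(C)C(=O)CCc2ccc(O)cc2)cc1` gives 14.6 h, which lies within the scatter of compound 2, while compound 1 `CN(/N=N/c1ccc(C#N)cc1)C(=O)CCc1cccc(O)c1` gives 2.7 h; the only measured step, a 2.9-fold higher number from compound 1 to compound 2 (0.46 log units; beyond the scatter), came with methoxycarbonyl in place of cyano on an aromatic carbon. Compound 4 `COC(=O)c1ccc(/N=N/N(C)C(=O)CCCCc2ccc(O)cc2)cc1` differs from compound 2 by 2-(4-hydroxyphenyl)ethyl in place of 3-hydroxyphenyl on a saturated chain carbon, two bonds along the chain from a carbonyl carbon. Going by the values given here, no measured step touches the chain or the hydroxyphenyl group, so that one step offers no direct guide. In this assay the change to compound 4 is therefore expected to bring a 1.2-fold higher number from compound 2 to compound 4 (0.06 log units; within the scatter), within the scatter. Compound 4 is estimated at 9 h, with a range of 4 h to 18 h.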

Compound 4, half-life in the plasma assay: 17.5 h
For compound 4 the middle estimate is 1.9-fold (0.29 log units) below the measured one; measured number inside the range.
By their numbers in the plasma assay, from the lowest: compound 1; then compounds 2, 3 and 4 (each within the scatter of the next, the first and the last beyond it).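

For the compounds shown here, in the plasma assay the first change at this chain position, 2-(4-hydroxyphenyl)ethyl in place of 3-hydroxyphenyl, brings a 2.2-fold higher number from compound 2 to compound 4 (0.35 log units; beyond the scatter). In a physicochemical assay for metabolic stability, read by HPLC, in phosphate buffer, at pH 7.4 (a lower number here means that the compound disappears faster, a higher number that the compound lasts longer), compound 2 gives 94.7 h and compound 4 gives 124 h, which is a 1.3-fold higher number from compound 2 to compound 4 (0.12 log units; within the scatter), so a step beyond the scatter appears in the plasma assay alone. Nothing at hand accounts for this difference between the two read-outs. The step alters the chain and the place of the hydroxyl together, and the compounds shown do not separate the two. Going by these compounds, how a longer chain, or an amine in place of the hydroxyl, would fare in the plasma assay stays open.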